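The source may hold more compounds than are shown below. What is called first, only, known or untested is meant among the compounds shown, and "the series" means these compounds.

The measured compounds are three. Compound 1 `NC(=O)c1cc(Cl)c2c(Cl)c(C#CCO)n([C@H]3CCCNC3)c2n1` gives 301 nM in a functional assay on KG-1 cells (Homo sapiens) for antiproliferative activity; on this read-out lower numbers stand for an effect already at smaller amounts and higher numbers for an effect only at larger amounts of compound. Compound 2 `CC1(CC#Cc2c(Cl)c3c(Cl)cc(C(N)=O)nc3n2[C@H]2CCCNC2)COC1` gives 289 nM. Compound 3 `CN1CC(C#Cc2c(Cl)c3c(Cl)cc(C(N)=O)nc3n2[C@H]2CCCNC2)CC1=O` gives 155 nM.

Compound 3 has the lowest number of the three, yet its gaps to compound 2 and to compound 1 are both within the scatter, so no order among them can be claimed. Compound 4 `CC(O)CC#Cc1c(Cl)c2c(Cl)cc(C(N)=O)nc2n1[C@H]1CCCNC1` differs from compound 3 by 2-hydroxypropyl in place of 1-methyl-5-oxopyrrolidin-3-yl on a triple-bonded carbon. Among the measured compounds shown here, the steps that bear on this change are a 1.9-fold lower number from compound 1 to compound 3 (0.29 log units; within the scatter) and a 1.9-fold lower number from compound 2 to compound 3 (0.27 log units; within the scatter), each exchanging a chain on the triple-bonded carbon for the 1-methyl-5-oxopyrrolidin-3-yl ring, each within the scatter. Returning to a chain, here 2-hydroxypropyl, is therefore expected to give at most a small rise, not beyond the scatter. Compound 4 is estimated at 250 nM, between 120 nM and 520 nM. The expected step is a 1.6-fold higher number from compound 3 to compound 4 (0.21 log units; within the scatter).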

Compound 4, half-maximal effective concentration: 48 nM
Compound 4: middle estimate off by 5.2-fold (0.72 log units), on the high side; the measured number lies below the stated range.
By their numbers in this assay, from the lowest: compound 4; then compounds 3, 2 and 1 (each within the scatter of the next).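

With 2-hydroxypropyl on the triple-bonded carbon, this position gives the first steps beyond the scatter in this assay (a 3.2-fold lower number from compound 3 to compound 4 (0.51 log units; beyond the scatter); a 6.0-fold lower number from compound 2 to compound 4 (0.78 log units; beyond the scatter); a 6.3-fold lower number from compound 1 to compound 4 (0.80 log units; beyond the scatter)), whereas the earlier compounds had shown none. Compound 1 also carries a hydroxy group on its chain, so a hydroxy group alone does not go with the lower number. No evidence is available to explain these steps. From the compounds shown here alone, it remains open whether a longer chain bearing the hydroxy group, or an amine in place of that hydroxy group, would keep the lower number.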